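Methylsulfamoyl to (2-methoxyethoxy)carbonyl: expected inhibition

The source may hold more compounds than are shown below. What is called first, only, known or untested is meant among the compounds shown, and "the series" means these compounds.

Of the compounds shown here, two of this set carry numbers so far. Compound 1 `CCOC(=O)c1cccc(-c2ccc(C)cc2)c1` gives 63% in an assay on COS-7 cells for inhibition of patatin-like phospholipase domain-containing protein 2 (Mus musculus), tested at 200 uM; a higher number here means more inhibition at the concentration tested (going by the name of the read-out), a lower number less inhibition. Compound 2 `CCOc1ccc(-c2cccc(S(=O)(=O)NC)c2)cc1` gives 47% in this assay, which is the lowest of the two numbers; the nearest, compound 1, lies higher by a gap beyond the usual scatter of this read-out.

Compound 3 `CCOc1ccc(-c2cccc(C(=O)OCCOC)c2)cc1` is the next to be measured in this assay. It differs from compound 2 in one place: (2-methoxyethoxy)carbonyl in place of methylsulfamoyl on an aromatic carbon. For the measured compounds named here, no step between two measured compounds is available to calibrate this change, so the two values measured so far are the only guide.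

The step of a number 9 percentage points higher from compound 2 to compound 3 (within the scatter) is expected to be upward and of moderate size, at the edge of the scatter rather than clearly beyond it, because compound 1, carrying a different group at the same place, gives 63%. Going by the values given here, compound 3 is therefore estimated to give about 56% in this assay, with a plausible range from 38% to 72%; the outcome remains uncertain with only two reference values.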

Compound 3, a percentage reported as inhibition, at one concentration (the size of the read-out at that concentration, not a potency): 89%
For compound 3 the middle estimate is 33 percentage points below the measured one, and the stated range ends below it.
By their numbers in this assay, from the lowest: compound 2; then compound 1; then compound 3.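

Replacing methylsulfamoyl with (2-methoxyethoxy)carbonyl on this aromatic carbon gives a number 42 percentage points higher from compound 2 to compound 3 (beyond the scatter) in this assay with the rest of the molecule unchanged, so the read-out at this place clearly depends on the group it carries. For the compounds shown here, this is the first single-place step, since compound 1 and compound 2 differ in more than one place and could not isolate this position. It also shows that the methylsulfamoyl group, with its sulfur and its hydrogen-bond donor, is not needed for inhibition here, as the entering group has neither and compound 3 still gives the higher number. Nothing measured here explains the size of this step.

The step alone does not separate the loss of methylsulfamoyl from the gain of the 2-methoxyethoxy chain. On these data alone, a methoxycarbonyl group, a methylcarbamoyl group or a carboxylic acid at this place on the core of compound 3 would help divide the effect between the carbonyl link and the chain, and it remains open whether the same exchange would hold on the core of compound 1.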